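The compounds below may be only part of what the source reports. "The series", "measured", "known", "first", "only" and "open" are said of these compounds alone.

Compound 2, whose structure is `Cc1ccc(-n2cc(C(=O)Nc3cc(F)cc(F)c3)c(=O)c3ccc(N(C)C)nc32)cc1OCCCCCCC[N+]1(C)CCCC1`, sits in the middle of three measured compounds. In an assay on LX2 cells for inhibition of COL1A1 promoter (Homo sapiens), read by a luciferase reporter, with a stated time of 24 h, tested at 50 uM (a higher number here means a stronger effect of the compound at the concentration tested, a lower number a weaker effect), compound 2 gives 55.9%. Compound 1, built as `Cc1ccc(-n2cc(C(=O)Nc3cc(F)cc(F)c3)c(=O)c3ccc(N(C)C)nc32)cc1OCCCCCCC[N+]12CCN(CC1)CC2`, gives 9.71% in this assay, and compound 3, built as `CN(C)c1ccc2c(=O)c(C(=O)Nc3cc(F)cc(F)c3)cn(-c3ccc(Cl)c(OCCCCCCC[N+]4(C)CCCC4)c3)c2n1`, gives 76.1%. The step of a number 46.2 percentage points higher from compound 1 to compound 2 (beyond the scatter) and the step of a number 20.2 percentage points higher from compound 2 to compound 3 (beyond the scatter) set compound 2 below compound 3 and well above compound 1.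

Compound 4 is the unmeasured structure `Cc1ccc(-n2cc(C(=O)Nc3cc(F)cc(F)c3)c(=O)c3ccc(N(C)C)nc32)cc1OCCCCCCC[N+]1(C)CCCCC1`. It differs from compound 2 as follows: a group of 7 heavy atoms (6 carbon, 1 nitrogen; one six-membered non-aromatic ring with 1 hetero atom) in place of a group of 6 heavy atoms (5 carbon, 1 nitrogen; one five-membered non-aromatic ring with 1 hetero atom), on a saturated chain carbon, seven bonds along the chain from an oxygen on an aromatic ring. Among the measured compounds shown here, the step that bears on this change is the one from compound 1 to compound 2, which alters the same charged ring group on the chain and gave a number 46.2 percentage points higher from compound 1 to compound 2 (beyond the scatter). That step, however, swapped two fused rings for one ring; the present change only adds one carbon to a single ring and keeps the charge. A smaller step is therefore expected here, in either direction or none beyond the scatter. For compound 4 the expected value in this assay is 58%, within a range of 38% to 78%, which means an expected step of a number 2.1 percentage points higher from compound 2 to compound 4 (within the scatter).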

Compound 4, a percentage reported as inhibition, at one concentration (the size of the read-out at that concentration, not a potency): 45.1%
The estimate for compound 4 lay 12.9 percentage points above the measured number, within the range that was stated.
By their numbers in this assay, from the lowest: compound 1; then compound 4; then compound 2; then compound 3.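

At the end of this chain, in this assay, the size of a single charged ring matters: a six-membered ring in place of a five-membered one, with the charge kept, gives a number 10.8 percentage points lower from compound 2 to compound 4 (beyond the scatter). The group with two six-membered rings remains far behind the single six-membered ring, with a number 35.4 percentage points higher from compound 1 to compound 4 (beyond the scatter), so most of the low read-out of compound 1 goes with that two-ring group and not with ring size alone. Nothing available explains why the six-membered ring gives the lower read-out.

The compounds shown leave open how a seven-membered ring or an uncharged tertiary amine would fare at the same chain end. They also leave open whether the chloro group of compound 3 would raise the read-out when paired with the six-membered ring, and how a shorter or longer chain would alter these differences.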